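This account rests on a few compounds, and the source may have more. Where it says the series, first, only, none or still open, it means among the compounds named here.

Compound 3 `COC(=O)N[C@H](C(=O)N1CCC[C@H]1C(=O)Nc1ccc([C@@H]2CC[C@@H](c3ccc(NC(=O)[C@@H]4CCCN4C(=O)[C@@H](NC(=O)OC)C(C)C)cc3)N2c2ccc(F)cc2)cc1)C(C)C` has the highest number of the three compounds measured in an ADME assay on the whole organism for pharmacokinetics, with Rattus norvegicus as the target, at a dose of 3 mg/kg by the oral route; on this read-out lower numbers stand for lower exposure and higher numbers for higher exposure at the dose given: compound 3 gives 222 nM. Compound 1 `COC(=O)N[C@H](C(=O)N1CCC[C@H]1C(=O)Nc1ccc([C@H]2CC[C@H](c3ccc(NC(=O)[C@@H]4CCCN4C(=O)[C@@H](NC(=O)OC)C(C)C)cc3)N2c2ccc(C(F)(F)F)cc2)cc1)C(C)C` in this assay gives 221 nM, which sits within the scatter of compound 3 so that no order between the two can be claimed. Going by the values given here, compound 2 `COC(=O)N[C@H](C(=O)N1CCC[C@H]1C(=O)Nc1ccc([C@@H]2CC[C@@H](c3ccc(NC(=O)[C@@H]4CCCN4C(=O)[C@@H](NC(=O)OC)[C@@H](C)OC)cc3)N2c2ccc(F)cc2)cc1)[C@@H](C)OC` in this assay gives 78.8 nM, the only value beyond the scatter of compound 3 and the lowest exposure in the set.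

Compound 4 `COC(=O)N[C@H](C(=O)N1CCC[C@H]1C(=O)Nc1ccc([C@H]2CC[C@H](c3ccc(NC(=O)[C@@H]4CCCN4C(=O)[C@@H](NC(=O)OC)C(C)C)cc3)N2c2ccc(F)cc2)cc1)C(C)C` has not been measured in this assay. Against compound 3 the change is the two compounds have the same atoms and bonds and differ only in configuration as drawn: 2 of 6 stereo elements differ; a stereocentre at a saturated ring carbon is drawn S in compound 3 and R in compound 4; a stereocentre at a saturated ring carbon is drawn S in compound 3 and R in compound 4. Among the compounds with values here, no step between measured compounds of the set isolates such a change in configuration, so the direction cannot be read from the data. Compound 1 and compound 3 differ in configuration at the same ring carbons and in one further place and yet give values within the scatter of each other, which does not suggest a large effect. The step from compound 3 to compound 4 in this assay is expected to be small, a 1.2-fold lower number from compound 3 to compound 4 (0.09 log units; within the scatter), and not beyond the scatter. Compound 4 in this assay is therefore estimated at 180 nM, with a range from 60 nM to 550 nM.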

Compound 4, maximal plasma concentration in the Rattus norvegicus assay: 1610 nM
Compound 4: middle estimate off by 8.9-fold (0.95 log units), on the low side, and the stated range ends below it.
By their numbers in the Rattus norvegicus assay, from the lowest: compound 2; then compounds 1 and 3 (each within the scatter of the next); then compound 4.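

In the Rattus norvegicus assay compound 3 gives 222 nM and compound 4 gives 1610 nM, and this exposure gain, a 7.3-fold higher number from compound 3 to compound 4 (0.86 log units; beyond the scatter), belongs to the configuration at the two saturated ring carbons alone, as shown by: the fact that compounds 3 and 4 differ only in the configuration as drawn. With that configuration held, fluoro in place of trifluoromethyl on an aromatic carbon also matters in the Rattus norvegicus assay, a 7.3-fold higher number from compound 1 to compound 4 (0.86 log units; beyond the scatter), so the close values of compound 1 and compound 3, which differ in more than one place, did not mean that either change was without effect. In a physicochemical assay for solubility, in phosphate buffer, measured as kinetic solubility, at pH 7.2 (on this read-out higher numbers stand for higher solubility and lower numbers for lower solubility), compound 3 gives 4100 nM and compound 4 gives 6000 nM; the configuration change stays within the scatter, a 1.5-fold higher number from compound 3 to compound 4 (0.17 log units; within the scatter), so this read-out does not follow the rise in exposure.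

From the compounds shown here alone, whether the configuration step carries over to the trifluoromethyl compounds or to the side chains of compound 2 stays open. Also open, going by these compounds, is how a chloro, a nitrile or an amine on that aromatic carbon would compare with fluoro.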